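The source may hold more compounds than are shown below. What is called first, only, known or untested is meant among the compounds shown, and "the series" means these compounds.

Compound 1 `Cc1cc(CCC(=O)O)ccc1-c1noc(-c2ccc(OC(C)C)c(C#N)c2)n1`: 0.2 L/kg
Compound 2 `Cc1cc([C@@H]2C[C@H]2C(=O)O)ccc1-c1noc(-c2ccc(OC(C)C)c(C(F)(F)F)c2)n1`: 1.1 L/kg

In an in vivo ADME assay on the whole organism (strain Sprague-Dawley) for pharmacokinetics, with Rattus norvegicus as the target (a higher number here means that more of the compound sits outside the plasma, a lower number that more of the compound stays in the plasma), compound 2 stands highest of the two at 1.1 L/kg. Compound 1 gives 0.2 L/kg. The gap between these two values lies beyond the scatter. Compound 3 `Cc1cc(C(C)CC(=O)O)ccc1-c1noc(-c2ccc(OC(C)C)c(C(F)(F)F)c2)n1` has not yet been measured. In it, 1-(carboxymethyl)ethyl stands in place of 2-carboxycyclopropyl on an aromatic carbon, meta to a methyl group and para to a large group (1-(carboxymethyl)ethyl in place of 2-carboxycyclopropyl on an aromatic carbon), and the rest of compound 2 is kept. Within the data shown here, no measured pair shows this exchange alone, so the data give no size for it. The expectation therefore starts from compound 2 (1.1 L/kg), and no step beyond the scatter is expected in this assay, with only a slight lean downward. The expected change is small, a 1.2-fold lower number from compound 2 to compound 3 (0.09 log units; within the scatter) by this estimate. For compound 3 the estimated value is 0.9 L/kg with an expected range from 0.45 L/kg to 1.8 L/kg.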

Compound 3, volume of distribution at steady state: 0.6 L/kg
Compound 3: middle estimate off by 1.5-fold (0.18 log units), on the high side; measured number inside the range.
By their numbers in this assay, from the lowest: compound 1; then compounds 3 and 2 (each within the scatter of the next).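

At this position, on an aromatic carbon meta to a methyl group and para to a large group, 1-(carboxymethyl)ethyl in place of 2-carboxycyclopropyl gives a 1.8-fold lower number from compound 2 to compound 3 (0.26 log units; within the scatter) in this assay and so stays inside the usual spread of repeats. The three-membered ring and its 2 defined stereocentres can thus give way to an open chain, with the same count of heavy atoms, without a step that this read-out can separate from the scatter. Nothing measured here speaks to the reason for this result.

On these data alone, compound 1 differs from compound 2 and compound 3 in more than one place, so what the nitrile does alone in place of trifluoromethyl stays unknown. Also open, as far as these compounds go, is whether a longer chain before the carboxylic acid, or an amine in its place, would hold the number in this range.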